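Stretching a methoxy into pentyloxy at the solubility floor

The compounds below may be only part of what the source reports. "The series", "measured", "known", "first", "only" and "open" are said of these compounds alone.

In a physicochemical assay for solubility (a lower number here means a less soluble compound, a higher number a more soluble compound), compound 1 `CC(C)(C)c1ccc(NC(=O)N2Cc3ccc(S(=O)(=O)Nc4ccc(F)cc4)cc3C2)cc1` gives < 0.07 ug/mL, which is a limit and not a number. Compound 3 `COc1ccc(NS(=O)(=O)c2ccc3c(c2)CN(C(=O)Nc2ccc(C(C)(C)C)cc2)C3)c(F)c1` gives < 0.06 ug/mL, which is also a limit of the assay. Going by the values given here, compound 2 `COc1cc(F)ccc1NS(=O)(=O)c1ccc2c(c1)CN(C(=O)Nc1ccc(C(C)(C)C)cc1)C2` gives 0.607 ug/mL, the only true number so far.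

Methoxy in place of hydrogen on an aromatic carbon gave an at least 8.6-fold higher number from compound 1 to compound 2 (0.93 log units; beyond the scatter). With 2-fluoro-4-methoxyphenyl in place of 4-fluoro-2-methoxyphenyl on a sulfonamide nitrogen, the data show an at least 10-fold lower number from compound 2 to compound 3 (1.00 log units; beyond the scatter). The remaining comparison is a step that the two limits leave unreadable from compound 1 to compound 3.

Compound 4 `CCCCCOc1ccc(NS(=O)(=O)c2ccc3c(c2)CN(C(=O)Nc2ccc(C(C)(C)C)cc2)C3)c(F)c1` turns the methoxy of compound 3 into pentyloxy, with butyl in place of hydrogen on a saturated chain carbon bound to an oxygen on an aromatic ring. Among the compounds with values here, none of the measured steps lengthens a chain on that oxygen, so they are only a loose guide. Compound 4 is built on compound 3, the low end of an at least 10-fold lower number from compound 2 to compound 3 (1.00 log units; beyond the scatter), so no readable rise is expected. The expected change is a step that the limit leaves unreadable from compound 3 to compound 4. For compound 4 the estimate is 0.05 ug/mL, with an expected range from 0.01 ug/mL to 0.3 ug/mL, and a reading that is only a limit is likely.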

Compound 4, solubility: < 0.06 ug/mL
Compound 4: no number, only a limit (the forecaster's own chance of this, stated with the estimate: 80%); the middle value is on the limit's open side.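

In this assay the step between compound 3 and compound 4 cannot be read, since both readings are limits and not numbers: the limit of < 0.06 ug/mL in this assay, at which 2 of the 4 values shown sit. The compounds shown leave open whether going from methoxy to pentyloxy moves the number in this assay at all.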